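Swapping an ethylphenyl for a naphthyl on a shared core

The compounds below may be only part of what the source reports. "The series", "measured", "known", "first", "only" and "open" are said of these compounds alone.

Of the compounds shown here, three built on one shared core have been tested in a functional assay on NCI-H322M cells (Homo sapiens) for inhibition, read by sulforhodamine B assay, with a stated time of 48 h, tested at 10 uM; on this read-out lower numbers stand for less inhibition and higher numbers for more inhibition at the one concentration tested (going by the name of the read-out). Compound 1 `c1ccc2c(-c3cn4ccnc4c(-c4ccc5ncn(C6CCCCC6)c5c4)n3)cccc2c1` carries a naphthalen-1-yl group and gives 4.74%. Compound 2 `CC(=O)c1ccc(-c2cn3ccnc3c(-c3ccc4ncn(C5CCCCC5)c4c3)n2)cc1` gives 1.19%, and the step of a number 3.6 percentage points lower from compound 1 to compound 2 (within the scatter) shows that exchanging the naphthalen-1-yl for a 4-acetylphenyl made no difference beyond the scatter. Compound 3 `CCc1ccc(-c2cn3ccnc3c(-c3ccc4ncn(Cc5ccccc5)c4c3)n2)cc1` gives 0.89%; its value sits close to that of compound 2 and that of compound 1, and none of the three numbers is separated from another by more than the usual scatter, so all three compounds look alike in this assay, with weak inhibition at the single concentration tested.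

Compound 4 `c1ccc(Cn2cnc3ccc(-c4nc(-c5cccc6ccccc56)cn5ccnc45)cc32)cc1` has not yet been measured. It differs from compound 3 in one place: naphthalen-1-yl in place of 4-ethylphenyl on an aromatic carbon. Among the measured compounds shown here, no measured step covers exactly this exchange. The nearest guide is the step from compound 1 to compound 2, which involved the same naphthalen-1-yl group and stayed within the scatter, and compound 1 itself, which carries a naphthalen-1-yl and gives a low number. The expected step of a number 2.6 percentage points higher from compound 3 to compound 4 (within the scatter) is therefore small, with no change beyond the scatter. Compound 4 is estimated at 3.5%, within a range from -5% to 12%.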

Compound 4, a percentage reported as inhibition, at one concentration (the size of the read-out at that concentration, not a potency): 1.34%
For compound 4 the middle estimate is 2.2 percentage points above the measured one, within the range that was stated.
By their numbers in this assay, from the lowest: compounds 3, 2, 4 and 1 (each within the scatter of the next).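

In this assay, the exchange of 4-ethylphenyl for naphthalen-1-yl on the aromatic carbon of the shared core gives a number 0.5 percentage points higher from compound 3 to compound 4 (within the scatter) and so leaves the read-out unchanged, even though the entering group brings a second six-membered aromatic ring. The earlier compounds shown here offered no direct comparison at the aromatic nitrogen, but with naphthalen-1-yl held constant, benzyl in place of cyclohexyl there gives a number 3.4 percentage points lower from compound 1 to compound 4 (within the scatter) and likewise makes no difference that can be told from the scatter. No measurement shown here accounts for these numbers staying so close together.

Going by these compounds, every exchange so far has swapped one carbon-only group for another at each of these places, and all the numbers are low, so it remains unknown whether either place can affect inhibition at all. An amine or a carboxylic acid on the aromatic carbon, or a longer chain on the aromatic nitrogen, would test whether a group of a different kind can move the number beyond the scatter.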